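The source may hold more compounds than are shown below. What is called first, only, known or untested is meant among the compounds shown, and "the series" means these compounds.

In a functional assay on Bel-7402 cells (Homo sapiens) for inhibition, read by MTT assay, with a stated time of 24 h, tested at 1 ug/mL (on this read-out lower numbers stand for less inhibition of growth and higher numbers for more inhibition of growth at the one concentration tested), compound 1 `CC(=O)SCCC(CCCCC(=O)O)SC(C)=O` gives 12.8% and compound 2 `O=C(CCCCC1CCSS1)Nc1ccc([N+](=O)[O-])c(C(F)(F)F)c1` gives 7.46%. Among the compounds with values here, these two values lie within the usual scatter of each other, so compound 1 stands level with the only other measured compound. Compound 3 `CC(=O)SCCC(CCCCC(=O)Nc1ccccc1)SC(C)=O` keeps the core of compound 1 but carries anilino in place of hydroxy on a carbonyl carbon. Within the data shown here, no measured pair shows what such a change does, so no step beyond the scatter is expected in this assay. The expected step is a number 2.2 percentage points higher from compound 1 to compound 3 (within the scatter). The estimate for compound 3 is 15%, with an expected range of 5% to 32%.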

Compound 3, percent growth inhibition at one concentration: 2.84%
Compound 3: the middle estimate sits 12.2 percentage points above what was measured; the measured number lies below the stated range.
By their numbers in this assay, from the lowest: compounds 3, 2 and 1 (each within the scatter of the next).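

Within the data shown here, this is the first pair that differs in one place, and it gives a first reading for this carbonyl carbon. In this assay, anilino in place of hydroxy gives a number 10 percentage points lower from compound 1 to compound 3 (within the scatter) and so brings a six-membered aromatic ring of carbon only without a step beyond the scatter. Nothing available offers an explanation for this result.

Still open, as far as these compounds go, is whether a smaller group such as methylamino, or a benzylamino group with a longer chain to its ring, would give a clear step on this carbonyl carbon.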